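A few compounds are considered here, and "the series" means these few. Any claim that something is new, unique, unknown or untested is made for them only; others in the source may bear on it.

Of the compounds shown here, three have so far been tested in a functional assay for antagonist activity at 5-hydroxytryptamine receptor 4 (Cavia porcellus); on this read-out higher numbers stand for higher potency (the scale is a negative logarithm) and lower numbers for lower potency. Compound 2 `CC(C)n1c(=O)n(C(=O)NCCN2CCN(C)CC2)c2cc(F)ccc21` gives 6.88, the highest of the two numbers recorded, while compound 1 `CN1CCN(CCCNC(=O)n2c(=O)n(C3CC3)c3ccccc32)CC1` gives 6.4, a gap beyond the usual scatter. For compound 3 `CN1CCN(CCNC(=O)n2c(=O)n(C)c3ccccc32)CC1` this assay returns only < 6, a limit rather than a number: the limit of < 6 in this assay, at which 1 of the 3 values shown sits. Going by the values given here, compound 4 `CC(C)n1c(=O)n(C(=O)NCCN2CCN(C)CC2)c2cc(Cl)ccc21` has not yet been measured; relative to compound 2 the single change is chloro in place of fluoro on an aromatic carbon. Among the compounds with values here, no measured pair isolates this change, so the step in this assay is expected to be small, with no clear direction beyond the scatter. The step expected is a number 0.12 log units higher from compound 2 to compound 4 (within the scatter). Compound 4 is therefore estimated at 7, within the range 6.5 to 7.5.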

Compound 4, negative logarithm of the antagonist equilibrium constant: < 6
Compound 4 gave a limit, no number; the forecaster's own chance of this, stated with the estimate: 3%; at least 1.00 log units between middle value and limit.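

Chloro in place of fluoro on this aromatic carbon is the first single change that can be read in this assay, and it is not a neutral swap: the step is a number at least 0.88 log units lower from compound 2 to compound 4 (beyond the scatter). The result for compound 4 is a limit, so the step has a bound but no exact size. This limit is now shared by two compounds: the limit of < 6 in this assay, at which 2 of the 4 values shown sit.

The compounds shown leave open whether hydrogen, methoxy or a nitrile on this carbon would keep the potency of compound 2. They also leave open whether the loss with chloro would recur on a core with a longer chain.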